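From Amino to Trifluoromethyl on a Shared Core

The source may report more compounds than this note shows. Statements on the series, on what has been measured and on what is new or still open speak of the compounds shown alone.

Of the compounds shown here, three built on one core have been measured in an assay on membranes from brain for binding affinity to adenosine receptor A1 (Rattus norvegicus), read by radioligand binding; a higher number here means a weaker inhibitor, a lower number a stronger inhibitor. Compound 1 `Cc1nn(C)c2c(O)nc(-c3ccccc3)nc12` carries an unsubstituted phenyl ring and gives 1020 nM. Compound 2 `Cc1ccc(-c2nc(O)c3c(n2)c(C)nn3C)cc1` adds a methyl to that ring and gives 400 nM, while compound 3 `Cc1nn(C)c2c(O)nc(-c3ccc(N)cc3)nc12` adds an amino instead and gives 380 nM. Compound 3 has the lowest number of the three, yet its gap to compound 2 is within the scatter, so the two cannot be ranked against each other; only compound 1 stands apart, with a 2.7-fold lower number from compound 1 to compound 3 (0.43 log units; beyond the scatter).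

Compound 4 `Cc1nn(C)c2c(O)nc(-c3ccc(C(F)(F)F)cc3)nc12` is the next step: trifluoromethyl in place of amino on an aromatic carbon. Among the measured compounds shown here, two measured steps bear on this position. Placing a methyl or an amino where compound 1 has hydrogen gave a 2.6-fold lower number from compound 1 to compound 2 (0.41 log units; beyond the scatter) and a 2.7-fold lower number from compound 1 to compound 3 (0.43 log units; beyond the scatter), and exchanging one for the other gave a 1.1-fold lower number from compound 2 to compound 3 (0.02 log units; within the scatter). Both groups behaved alike, so a third group at the same place is expected to stay close in this assay, with no step beyond the scatter. The trifluoromethyl has no measured counterpart among these compounds, so a wider range is warranted. The expected step is a 1.4-fold higher number from compound 3 to compound 4 (0.16 log units; within the scatter). Compound 4 is therefore estimated at 550 nM, within a range from 200 nM to 1600 nM.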

Compound 4, half-maximal inhibitory concentration: 463 nM
Estimate against measurement, compound 4: 1.2-fold (0.07 log units) above, within the range that was stated.
By their numbers in this assay, from the lowest: compounds 3, 2 and 4 (each within the scatter of the next); then compound 1.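

In this assay, trifluoromethyl on this aromatic carbon, para to a large group, falls in with methyl and amino: the steps are a 1.2-fold higher number from compound 3 to compound 4 (0.09 log units; within the scatter) and a 1.2-fold higher number from compound 2 to compound 4 (0.06 log units; within the scatter), so compounds 2, 3 and 4 cannot be ranked against one another. The replacement of hydrogen still shows up for this third group, with a 2.2-fold lower number from compound 1 to compound 4 (0.34 log units; beyond the scatter), which extends to trifluoromethyl what the earlier compounds had shown only for methyl and amino. Amino and trifluoromethyl differ in their hydrogen-bond donors, hydrogen-bond acceptors and heavy atoms, yet the step between them stays within the scatter, and nothing among the data shown says why.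

As far as these compounds go, all three groups sit at the same place on the ring, so how any of them would behave elsewhere on that ring remains open. From the compounds shown here alone, it is also open whether this close grouping would hold for quite different groups at this place, such as a carboxylic acid, a methoxy group or a longer alkyl chain.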